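The compounds below may be only part of what the source reports. "The series", "measured", "known", "first", "only" and "open" are said of these compounds alone.

In a functional assay on A549 cells (Homo sapiens) for cytotoxicity, read by MTT assay, with a stated time of 72 h (on this read-out lower numbers stand for an effect already at smaller amounts and higher numbers for an effect only at larger amounts of compound), compound 1 `CCc1cccc2c(OC)c(-c3occ(C)c3C(=O)OC)ccc12` gives 1.5 ug/mL. Compound 2 `CCc1cccc2c(OC)c(-c3occ(C)c3COC)ccc12` gives > 10 ug/mL, which is a limit of the assay and not a number, so its place on the scale is known only as the limit of > 10 ug/mL in this assay, at which 1 of the 2 values shown sits. Compound 3 `CCc1cccc2c(OC)c(-c3occ(C)c3COC(C)=O)ccc12` keeps the same core as compound 2 but has acetyl in place of methyl on an oxygen on a saturated carbon, so methoxymethyl becomes acetoxymethyl: acetyl in place of methyl on an oxygen on a saturated carbon. Going by the values given here, only one measured step bears on this change: an at least 6.6-fold higher number from compound 1 to compound 2 (0.82 log units; beyond the scatter). That step, which lies beyond the scatter, put methoxymethyl in place of methoxycarbonyl and so removed a carbonyl. The acetyl brings a carbonyl back, although in a different arrangement from the methoxycarbonyl. On the strength of that single step, compound 3 is expected to regain part of the lost effect, which would mean a move toward lower numbers in this assay, though a reading that again stops at the limit remains possible. The estimated step is an at least 2.0-fold lower number from compound 2 to compound 3 (0.30 log units; that floor lies within the scatter). For compound 3 the expected value is 5 ug/mL, with an estimated range from 1.5 ug/mL to 14 ug/mL.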

Compound 3, concentration for half-maximal effect: > 10 ug/mL
Compound 3 ended at the assay's limit (the forecaster's own chance of this, stated with the estimate: 30%); middle value at least 2.0-fold (0.30 log units) from the limit.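

Restoring a carbonyl on this side group does not by itself restore the effect: in this assay compound 3 gives > 10 ug/mL, which is a limit of the assay and not a number. Acetoxymethyl in place of methoxycarbonyl on this aromatic carbon gives an at least 6.6-fold higher number from compound 1 to compound 3 (0.82 log units; beyond the scatter), so among the compounds shown, a carbonyl somewhere in the group does not suffice, and only methoxycarbonyl gives a value that is not a limit. The step from methoxymethyl to acetoxymethyl cannot be read, as neither compound 2 nor compound 3 has a value that is a number: the limit of > 10 ug/mL in this assay, at which 2 of the 3 values shown sit.

From the compounds shown here alone, the true place of compound 2 and compound 3 on the scale stays open, so these two groups cannot be ranked against each other. Also open, going by these compounds, is whether a different group on this aromatic carbon, such as a carboxylic acid, an amide or a hydroxymethyl, would stay close to compound 1 or would end at the limit as well, and so how much of the effect depends on methoxycarbonyl in particular.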